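The source may report more compounds than this note shows. Statements on the series, on what has been measured and on what is new or still open speak of the compounds shown alone.

Three compounds of the series have been run in a functional assay on HeLa cells (Homo sapiens) for cytotoxicity, read by MTT assay, with a stated time of 72 h; a lower number here means a stronger inhibitor, a higher number a weaker inhibitor. Compound 1 `Cc1cc(S(=O)(=O)/N=C(\N)n2nccc2-c2ccccc2)c(SCc2ccccc2Cl)cc1Cl` gives 19000 nM, compound 2 `Cc1cc(-c2ccccc2)n(/C(N)=N/S(=O)(=O)c2cc(C)c(Cl)cc2SCc2ccccc2C)n1` gives 160000 nM, and compound 3 `Cc1cccc(CSc2cc(Cl)c(C)cc2S(=O)(=O)/N=C(\N)n2nccc2-c2ccccc2)c1` gives 8000 nM. Compound 2 stands highest of the three numbers; compound 1 is nearest to it and compound 3 furthest, both lying well below it.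

Going by the values given here, only one measured step touches the same place as the change now considered: a 2.4-fold lower number from compound 1 to compound 3 (0.38 log units; beyond the scatter), a swap of the aryl group on the saturated chain carbon bound to a sulfur.

Compound 4 `Cc1cc(-c2ccccc2)n(/C(N)=N/S(=O)(=O)c2cc(C)c(Cl)cc2SCc2ccc(C(F)(F)F)cc2)n1` differs from compound 2 by 4-(trifluoromethyl)phenyl in place of 2-methylphenyl on a saturated chain carbon bound to a sulfur. Among the compounds with values here, the one comparable swap was modest in size, and nothing measured so far carries a trifluoromethyl group, so the direction can be read only loosely from that step. A modest lowering in this assay is expected, but a step within the scatter would not surprise.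

The estimate for compound 4 is 60000 nM, with a range from 15000 nM to 250000 nM, an expected step of a 2.7-fold lower number from compound 2 to compound 4 (0.43 log units; beyond the scatter).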

Compound 4, half-maximal inhibitory concentration: 19000 nM
Compound 4: middle estimate off by 3.2-fold (0.50 log units), on the high side, within the range that was stated.
By their numbers in this assay, from the lowest: compound 3; then compounds 1 and 4 (each within the scatter of the next); then compound 2.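

In this assay, going by these compounds alone, the aryl group on the saturated chain carbon bound to a sulfur now shows a clear effect on the core of compound 2 as well, with an 8.4-fold lower number from compound 2 to compound 4 (0.93 log units; beyond the scatter), whereas the only earlier step at this place, a 2.4-fold lower number from compound 1 to compound 3 (0.38 log units; beyond the scatter), was on the core of compound 1. The larger entering group, 4-(trifluoromethyl)phenyl with 10 heavy atoms against 7 for 2-methylphenyl, goes with a lower number here, so added size at this place does not by itself raise the number in this pair. Nothing available explains the step.

The swap changes both the group and its place on the phenyl ring, so the two contributions cannot be separated with the compounds shown. On these data alone, it also remains open how this position responds to an amine or a carboxylic acid on that ring, or to a longer chain between the sulfur and the ring.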